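One Double Bond Geometry Changed in the Shared Core

The compounds below may be only part of what the source reports. "The series", "measured", "known", "first", "only" and "open" are said of these compounds alone.

Compound 1 `CC(=O)N[C@H](C)[C@@H](O)[C@@H](C)[C@@H]1OC(=O)CC/C=C(C)\C=C\[C@]2(C)CCC=C[C@@H]2/C=C(C)/C=C/[C@H]1C` and compound 2 `CC(=O)N[C@H](C)[C@@H](O)[C@@H](C)[C@@H]1OC(=O)/C=C/C=C(C)\C=C\[C@]2(C)CCC=C[C@@H]2/C=C(C)/C=C/[C@H]1C` share a core and differ in the linker. In a functional assay on RKO cells (Homo sapiens) for antiproliferative activity, read by resazurin assay, with a stated time of 72 h (a lower number here means a stronger inhibitor, a higher number a weaker inhibitor), compound 1 reaches only a limit, > 5000 nM. In this assay compound 2 gives 214 nM, the only numerical result so far. The other value, that of compound 1, is a limit (the limit of > 5000 nM in this assay, at which 1 of the 2 values shown sits). Compound 3 `CC(=O)N[C@H](C)[C@@H](O)[C@@H](C)[C@@H]1OC(=O)/C=C/C=C(C)/C=C/[C@]2(C)CCC=C[C@@H]2/C=C(C)/C=C/[C@H]1C` comes next: the two compounds have the same atoms and bonds and differ only in configuration as drawn: 1 of 12 stereo elements differ; a double bond is drawn Z in compound 2 and E in compound 3. Going by the values given here, no measured pair shows what such a flip does, so its size in this assay is open; a loss beyond the scatter seems somewhat more likely than a gain. Compound 3 is expected to give 600 nM, within 150 nM to 5000 nM. The expected step is a 2.8-fold higher number from compound 2 to compound 3 (0.45 log units; beyond the scatter).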

Compound 3, half-maximal inhibitory concentration: 1070 nM
Beside the measured number, compound 3's estimate is 1.8-fold (0.25 log units) below it; the range from low to high includes it.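

In this assay, the geometry of a single double bond matters on its own: changing it from Z to E gives a 5.0-fold higher number from compound 2 to compound 3 (0.70 log units; beyond the scatter). No atom or bond enters or leaves, so this weakening can be tied to the flip alone, because of how the two structures relate: the fact that compounds 2 and 3 differ only in the configuration as drawn. The earlier compounds shown here gave no measured pair of this kind.

From the compounds shown here alone, it remains open whether flipping the other double bonds of the shared core would have a similar effect. Also open, going by these compounds, is how a free amine in place of the acetyl amide would fare.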